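The source may report more compounds than this note shows. Statements on the series, on what has been measured and on what is new or still open speak of the compounds shown alone.

Within the data shown here, in a physicochemical assay for solubility, measured as kinetic solubility (on this read-out lower numbers stand for lower solubility and higher numbers for higher solubility), compound 1 (`O=C(Nc1ccnnc1)c1cc(N2CCCCC2)ccc1OCc1ccccc1`) gives 60000 nM, the only true number so far. Compound 2 (`O=C(Nc1cccc(F)c1)c1cc(C(F)(F)F)ccc1OCc1ccc(F)cc1`) reads < 1000 nM, which is a limit of the assay and not a number. Compound 1 therefore stands well clear of that limit. Compound 3 (`CN1CC2(C1)CN(c1ccc(OCc3ccccc3)c(C(=O)Nc3ccnnc3)c1)C2`) keeps the core of compound 1 and changes one group: a group of 8 heavy atoms (6 carbon, 2 nitrogen; 2 four-membered non-aromatic rings with 1 hetero atom each) in place of a group of 6 heavy atoms (5 carbon, 1 nitrogen; one six-membered non-aromatic ring with 1 hetero atom), on an aromatic carbon. The piperidin-1-yl group, on an aromatic carbon para to a benzyloxy group and meta to a (pyridazin-4-yl)carbamoyl group, gives way to a group with 2 four-membered non-aromatic rings. Among the measured compounds shown here, no measured pair of compounds shows a swap of this kind, so the expectation for this assay rests on judgement alone. The estimated step of a 1.8-fold higher number from compound 1 to compound 3 (0.26 log units; within the scatter) is a small rise, possibly no more than the usual scatter. Compound 3 is estimated at 110000 nM, with an expected range of 45000 nM to 220000 nM.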

Compound 3, solubility: 198000 nM
Compound 3: the middle estimate sits 1.8-fold (0.26 log units) below what was measured; the range from low to high includes it.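

In this assay, putting the group with 2 four-membered non-aromatic rings in place of piperidin-1-yl, on an aromatic carbon para to a benzyloxy group and meta to a (pyridazin-4-yl)carbamoyl group, gives a 3.3-fold higher number from compound 1 to compound 3 (0.52 log units; beyond the scatter). This is the only pair shown that differs in one place, so it is the first sign that the group at this position can move the read-out beyond the scatter, even from the high number of compound 1. No measurement shown gives a reason for this rise.

A single step cannot separate the effect of the two small rings from that of the second nitrogen in the entering group. From the compounds shown here alone, how a morpholin-4-yl or a piperazin-1-yl group at this position would compare remains open, as does whether the same swap would give a similar step on a different core.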